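Trifluoromethyl for ethyl on a sulfonamide anilide

The source may hold more compounds than are shown below. What is called first, only, known or untested is meant among the compounds shown, and "the series" means these compounds.

Of the compounds shown here, two with a shared core have been measured. Compound 1 `COc1cc(NC(=O)c2ccc(Cl)cc2)ccc1NS(=O)(=O)C(F)(F)F` carries a trifluoromethyl on its sulfonyl sulfur; compound 2 `CCS(=O)(=O)Nc1ccc(NC(=O)c2ccc(Cl)cc2)cc1Cl` carries an ethyl there and differs from compound 1 elsewhere as well, so the two are not a single-change pair. In an ADME assay on RAW264.7 cells (Mus musculus) for cytotoxicity, read by MTT assay, with a stated time of 48 h (on this read-out higher numbers stand for weaker inhibition and lower numbers for stronger inhibition), compound 1 gives 108000 nM. Compound 2 gives only a limit of the assay in this assay, > 250000 nM, so its standing is known only as a boundary, which is what the limit of > 250000 nM in this assay, at which 1 of the 2 values shown sits, records.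

Compound 3 `O=C(Nc1ccc(NS(=O)(=O)C(F)(F)F)c(Cl)c1)c1ccc(Cl)cc1` has not yet been measured. It is made from compound 2 by one change, (trifluoromethyl in place of ethyl on a sulfonyl sulfur). No measured pair shows this change by itself, so its size cannot be read from the numbers shown.

The expectation is therefore cautious: the step from compound 2 to compound 3, an at least 1.2-fold lower number from compound 2 to compound 3 (0.09 log units; that floor lies within the scatter), is expected to stay within the usual scatter, and compound 3 is expected to give about 200000 nM in this assay, somewhere between 80000 nM and 400000 nM, with a real chance that only a limit is reported again.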

Compound 3, half-maximal inhibitory concentration: 47200 nM
Estimate against measurement, compound 3: 4.2-fold (0.63 log units) above, outside the stated range (below it).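

In this assay, trifluoromethyl in place of ethyl on a sulfonyl sulfur can now be seen as a single change, and it gives an at least 5.2-fold lower number from compound 2 to compound 3 (0.72 log units; beyond the scatter), so what sits on this sulfur clearly matters to the read-out. Compound 2 stands at a limit of the assay, so that step gives only a floor and its true size stays unknown: the limit of > 250000 nM in this assay, at which 1 of the 3 values shown sits.

With trifluoromethyl kept on the sulfonyl sulfur, chloro in place of methoxy on an aromatic carbon gives a 2.3-fold lower number from compound 1 to compound 3 (0.36 log units; beyond the scatter), which shows that this second site also moves the number, though modestly, and in the direction of stronger inhibition.

The compounds shown leave open whether trifluoromethyl itself is needed on the sulfonyl sulfur, or whether a methyl, a longer chain such as propyl, or a phenyl ring there would shift the number in the same way. They also leave open how a fluoro or a nitrile would compare with chloro on that aromatic carbon, and whether ethyl combined with methoxy would again reach a limit.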